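The compounds below may be only part of what the source reports. "The series", "measured", "known", "first", "only" and "open" are said of these compounds alone.

Working notes on the shared core of compound 1 `N#Cc1cccc(C(=O)Nc2ccc3nc(NC(=O)C4CCCCC4)sc3c2)c1`, compound 2 `Cc1ccc(C(=O)Nc2ccc3nc(NC(=O)C4CCCCC4)sc3c2)cc1` and compound 3 `O=C(Nc1ccc2nc(NC(=O)C3CCCCC3)sc2c1)c1ccc(Cl)cc1Cl`, which differ only in the group on one carbonyl carbon. In a functional assay on WI-38 VA13 cells (Homo sapiens) for cytotoxicity (on this read-out lower numbers stand for an effect already at smaller amounts and higher numbers for an effect only at larger amounts of compound), compound 1 gives 0.52 ug/mL and compound 2 gives 5.1 ug/mL. For compound 3 this assay reports only a limit, > 4 ug/mL, which is all that is known of its place (the limit of > 4 ug/mL in this assay, at which 1 of the 3 values shown sits). The readable steps are a 9.8-fold higher number from compound 1 to compound 2 (0.99 log units; beyond the scatter) and an at least 7.6-fold higher number from compound 1 to compound 3 (0.88 log units; beyond the scatter); the remaining pair gives a step that the limit leaves unreadable from compound 2 to compound 3. Within the data shown here, compound 3 therefore stands at the upper, unreadable end of the three values, with compound 1 the only one carrying a number clearly below it.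

Compound 4 `CC(=O)Nc1ccc2nc(NC(=O)C3CCCCC3)sc2c1` is the next step: methyl in place of 2,4-dichlorophenyl on a carbonyl carbon. Among the measured compounds shown here, no measured step exchanges an aryl group for a methyl; each of the three swaps one aryl for another, so there is no direct precedent for size or direction. For the measured compounds named here, the only guidance is that both steps away from the nitrile compound, a 9.8-fold higher number from compound 1 to compound 2 (0.99 log units; beyond the scatter) and an at least 7.6-fold higher number from compound 1 to compound 3 (0.88 log units; beyond the scatter), raised the number by a modest amount, and compound 3 itself already sits at a limit. The expected step in this assay is a step that the limit leaves unreadable from compound 3 to compound 4. The estimate for compound 4 is 10 ug/mL, within 2 ug/mL to 50 ug/mL, with a real chance that this assay again reports only a limit.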

Compound 4, half-maximal effective concentration: 2.7 ug/mL
Compound 4: middle estimate off by 3.7-fold (0.57 log units), on the high side; low and high end bracket the measured number.
By their numbers in this assay, from the lowest: compound 1; then compounds 4 and 2 (each within the scatter of the next).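

In this assay, the group on this carbonyl carbon need not be an aryl group for the number to stay level with that of compound 2: methyl in place of 4-methylphenyl gives a 1.9-fold lower number from compound 2 to compound 4 (0.28 log units; within the scatter). The 3-cyanophenyl group stays apart from methyl as well, with a 5.2-fold higher number from compound 1 to compound 4 (0.72 log units; beyond the scatter), so compound 1 is the only one of the four whose readable steps to the others all lie beyond the scatter. Methyl in place of 2,4-dichlorophenyl gives an at least 1.4-fold lower number from compound 3 to compound 4 (0.17 log units; that floor lies within the scatter), and that step says little about the size of this change, while the step from compound 2 to compound 3 cannot be read, both resting on a limit: the limit of > 4 ug/mL in this assay, at which 1 of the 4 values shown sits.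

The compounds shown leave open whether the separation of compound 1 belongs to the nitrile itself or to the 3-cyanophenyl group as a whole. From the compounds shown here alone, it also remains open whether a non-aryl group other than methyl on this carbonyl carbon, such as a longer chain or an aminomethyl group, would stay level with compound 4 or move toward compound 1.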